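Replacing the 4-hydroxyphenyl group of compound 2

The source may report more compounds than this note shows. Statements on the series, on what has been measured and on what is new or still open speak of the compounds shown alone.

Measured in an ADME assay on NHDF cells (Homo sapiens) for cytotoxicity, read by MTT assay, with a stated time of 72 h; on this read-out lower numbers stand for stronger inhibition and higher numbers for weaker inhibition:
- compound 1 `COc1ccc(/C=C2\CCC/C(=C\c3cccc(Br)c3)C2=O)cc1OC`: 12400 nM
- compound 2 `COc1ccc(/C=C2\CCC/C(=C\c3ccc(O)cc3)C2=O)cc1OC`: 26100 nM

Of the two measured compounds, compound 2 stands highest at 26100 nM. Compound 3 `COc1ccc(/C=C2\CCC/C(=C\c3ccc(Cl)c(Cl)c3)C2=O)cc1OC` differs from it at a single place: 3,4-dichlorophenyl in place of 4-hydroxyphenyl on a double-bonded chain carbon bound to a double-bonded ring carbon. Among the compounds with values here, only one measured step bears on this change: a 2.1-fold higher number from compound 1 to compound 2 (0.32 log units; beyond the scatter). That modest step brought in 4-hydroxyphenyl in place of 3-bromophenyl at the same place. Compound 3 gives up 4-hydroxyphenyl again, so a step of similar modest size towards a lower number is expected in this assay. Within the data shown here, this expectation rests on one step alone, and no compound with 3,4-dichlorophenyl has yet been measured. Compound 1, at 12400 nM, is the closest guide. The expected change is a 2.1-fold lower number from compound 2 to compound 3 (0.32 log units; beyond the scatter). For compound 3 the estimated value is 12500 nM, with an expected range of 5500 nM to 28000 nM.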

Compound 3, half-maximal inhibitory concentration: 10100 nM
Compound 3: middle estimate off by 1.2-fold (0.09 log units), on the high side, within the range that was stated.
By their numbers in this assay, from the lowest: compounds 3 and 1 (each within the scatter of the next); then compound 2.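

In this assay, a second replacement of 4-hydroxyphenyl on the double-bonded chain carbon points the same way as the first, with 3,4-dichlorophenyl giving a 2.6-fold lower number from compound 2 to compound 3 (0.41 log units; beyond the scatter). Exchanging 3-bromophenyl for 3,4-dichlorophenyl at this place gives a 1.2-fold lower number from compound 1 to compound 3 (0.09 log units; within the scatter), so these two groups cannot be told apart here, and among the compounds shown, 4-hydroxyphenyl alone stands apart. No measurement shown gives a reason for these numbers.

It remains open whether the higher number of compound 2 goes with its hydroxyl group or with the absence of halogen, since the compounds shown include neither plain phenyl nor a methoxy group at this place. On these data alone, how an amine or a carboxylic acid on the phenyl group would behave here also remains open.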